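The source may hold more compounds than are shown below. What is called first, only, known or untested is meant among the compounds shown, and "the series" means these compounds.

In an ADME assay (liver, Mus musculus) for metabolic stability, using microsomes (on this read-out higher numbers stand for a longer-lived compound and lower numbers for a shorter-lived compound), compound 1 (`CCc1nc2cc(Cl)ccn2c1C(=O)NCc1ccc(-c2ccc(Cl)cc2)cc1`) gives > 1 h, which is a limit. Compound 2 (`CCc1nc2cc(Cl)ccn2c1C(=O)NCc1ccc(-c2ccc(C(=O)O)cc2)cc1`) gives > 2 h, also a limit. Within the data shown here, compound 3 (`CCc1nc2cc(Cl)ccn2c1C(=O)NCc1ccc(N2CCC(Cl)CC2)cc1`) gives 0.0867 h, the only actual number of the three, and it stands low, with large steps of an at least 11-fold lower number from compound 1 to compound 3 (1.06 log units; beyond the scatter) and an at least 23-fold lower number from compound 2 to compound 3 (1.36 log units; beyond the scatter). Compound 4 (`CCc1nc2cc(Cl)ccn2c1C(=O)NCc1ccc(-n2cc3c(c2)CCCC3)cc1`) is not yet measured and differs from compound 3 as follows: a group of 9 heavy atoms (8 carbon, 1 nitrogen; one five-membered aromatic ring with 1 hetero atom, one six-membered non-aromatic ring of carbon only) in place of a group of 7 heavy atoms (5 carbon, 1 nitrogen, 1 chlorine; one six-membered non-aromatic ring with 1 hetero atom), on an aromatic carbon. The entering group holds a five-membered aromatic ring, as the groups of compound 1 and compound 2 hold an aromatic ring, but also a six-membered non-aromatic ring of carbon only. Only part of an at least 11-fold lower number from compound 1 to compound 3 (1.06 log units; beyond the scatter) is therefore expected to be regained in this assay, an estimated rise given as a 4.6-fold higher number from compound 3 to compound 4 (0.66 log units; beyond the scatter). Compound 4 is expected at 0.4 h, with an estimated range of 0.1 h to 2 h.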

Compound 4, half-life: 1.04 h
Compound 4: middle estimate off by 2.6-fold (0.41 log units), on the low side, and the stated range covers the measured number.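

In this assay, the change on the aromatic carbon para to a large group gives a 12-fold higher number from compound 3 to compound 4 (1.08 log units; beyond the scatter), so a group without a six-membered aromatic ring of carbon only can also stand here with a far longer half-life than compound 3 shows. Against the carboxyphenyl group, the change gives an at least 1.9-fold lower number from compound 2 to compound 4 (0.28 log units; that floor lies within the scatter). The step to compound 4 from compound 1 cannot be read, as compound 1 stands at a limit: the limit of > 1 h in this assay, at which 1 of the 4 values shown sits.

The compounds shown leave open whether the five-membered aromatic ring alone, as a plain pyrrol-1-yl group, would give the same rise, or whether the fused carbon ring is also needed. They also leave open what a piperidin-1-yl group without its chlorine would give.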